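Adding a methyl group to the chloroaniline of compound 1

A few compounds are considered here, and "the series" means these few. Any claim that something is new, unique, unknown or untested is made for them only; others in the source may bear on it.

Measured compounds:
- compound 1, `O=C(CN1CCC(c2cccc[n+]2[O-])CC1)Nc1cccc(Cl)c1`: 62 nM
- compound 2, `C=Cc1cccc(C(=O)NCN2CCC(c3cccc[n+]3[O-])CC2)c1`: 68 nM
- compound 3, `CCOc1cccc(C(=O)NCN2CCC(c3cccc[n+]3[O-])CC2)c1`: 324 nM

All three were tested in a functional assay on HEK293 cells for agonist activity at D(4) dopamine receptor (Homo sapiens), read by FLIPR; a higher number here means that more compound is needed for the effect, a lower number that less compound is needed. Compound 1 and compound 2 give numbers that lie within the scatter of each other, so neither can be called more potent than the other. Among the compounds with values here, compound 3 stands apart: the only single change among the measured compounds is a 4.8-fold higher number from compound 2 to compound 3 (0.68 log units; beyond the scatter), and compound 1 sits a similar distance from compound 3.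

The new compound, compound 4, `Cc1ccc(Cl)cc1NC(=O)CN1CCC(c2cccc[n+]2[O-])CC1`, is made from compound 1 by a small change: methyl in place of hydrogen on an aromatic carbon. Within the data shown here, no measured step touches this position. Among the measured compounds shown here, the one step known, from compound 2 to compound 3, swaps one group for another on a different ring position in a different linker series, so it says nothing direct about a methyl entering here. For the measured compounds named here, with no matching precedent, the safest expectation in this assay is a number close to that of compound 1, with a wide margin on either side.

Compound 4 is therefore estimated at 80 nM, spanning 25 nM to 260 nM, meaning an expected step of a 1.3-fold higher number from compound 1 to compound 4 (0.11 log units; within the scatter).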

Compound 4, half-maximal effective concentration: 126 nM
Beside the measured number, compound 4's estimate is 1.6-fold (0.20 log units) below it, within the range that was stated.
By their numbers in this assay, from the lowest: compounds 1, 2 and 4 (each within the scatter of the next, the first and the last beyond it); then compound 3.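

In this assay, the change from 3-chlorophenyl to 5-chloro-2-methylphenyl gives a 2.0-fold higher number from compound 1 to compound 4 (0.31 log units; beyond the scatter), a modest step that lies just beyond the scatter. Within the data shown here, the earlier compounds offered no measured change on this ring, so this is the first sign that the place ortho to a large group and para to a chloro group is not indifferent: one added carbon atom is enough to shift the number, and here more compound is needed for the effect. Nothing available explains why the number shifts, so the step remains an observation without a cause.

A single methyl group at a single place cannot show whether the shift depends on size or on the kind of group, so an ethyl group, a methoxy group, a fluoro group or an amine at this same carbon could each respond differently. Going by these compounds, it also remains open whether methyl would produce a similar step without the chloro group, or at another carbon of the ring.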